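Swapping bromo for trifluoromethyl on a sugar-bearing core

The source may report more compounds than this note shows. Statements on the series, on what has been measured and on what is new or still open speak of the compounds shown alone.

Compound 2 `OC[C@H]1O[C@@H](n2cnc3c(NCc4cccc(Br)c4)ncnc32)[C@H](O)[C@@H]1O` gives 19700 nM in a functional assay on K562 cells (Homo sapiens) for antiproliferative activity, with a stated time of 72 h; a lower number here means a stronger inhibitor, a higher number a weaker inhibitor. Among the two plain numbers here it is the higher, with compound 1 `OC[C@H]1O[C@@H](n2cnc3c(NCc4ccc(F)cc4)ncnc32)[C@H](O)[C@@H]1O`, at 2700 nM, as its only neighbour; the change from the 4-fluorophenyl of compound 1 to the 3-bromophenyl of compound 2 brings a 7.3-fold higher number from compound 1 to compound 2 (0.86 log units; beyond the scatter). Compound 3 `OC[C@H]1O[C@@H](n2cnc3c(NCc4ccc(F)c(F)c4F)ncnc32)[C@H](O)[C@@H]1O` gives only a limit of the assay, > 166000 nM, and that is the limit of > 166000 nM in this assay, at which 1 of the 3 values shown sits. Set against compound 1 this is an at least 61-fold higher number from compound 1 to compound 3 (1.78 log units; beyond the scatter), and against compound 2 it is an at least 8.4-fold higher number from compound 2 to compound 3 (0.92 log units; beyond the scatter).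

Compound 4 `OC[C@H]1O[C@@H](n2cnc3c(NCc4cccc(C(F)(F)F)c4)ncnc32)[C@H](O)[C@@H]1O` differs from compound 2 in one place: trifluoromethyl in place of bromo on an aromatic carbon. For the measured compounds named here, no measured step exchanges bromo for trifluoromethyl, so the measured steps bear on it only loosely, showing that changes on this ring move the numbers by modest to large amounts. With nothing pointing either way, compound 4 is expected to sit near compound 2, giving an expected 1.0-fold higher number from compound 2 to compound 4 (0.01 log units; within the scatter). Compound 4 is estimated at 20000 nM, within 6000 nM to 70000 nM.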

Compound 4, half-maximal inhibitory concentration: > 166000 nM
Compound 4: only a limit was reported; the forecaster's own chance of this, stated with the estimate: 15%; at least 8.3-fold (0.91 log units) between middle value and limit.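

At this position, on an aromatic carbon meta to a large group, exchanging bromo for trifluoromethyl is not a neutral swap: an at least 8.4-fold higher number from compound 2 to compound 4 (0.92 log units; beyond the scatter). The earlier steps shown here changed the pattern on the ring or moved the substituent, whereas this one changes only the group at a single position and still gives a step beyond the scatter. Compared with the 4-fluorophenyl compound, the new compound also lies far up the scale, with an at least 61-fold higher number from compound 1 to compound 4 (1.78 log units; beyond the scatter), and compound 4 gives only a limit, so its step to compound 3, also a limit, cannot be read: the limit of > 166000 nM in this assay, at which 2 of the 4 values shown sit.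

The compounds shown give no reason for the loss of activity. On these data alone, it also remains open whether a methyl, a chloro, a methoxy or an amine at this position would keep a measurable number.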